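A few compounds are considered here, and "the series" means these few. Any claim that something is new, unique, unknown or untested is made for them only; others in the source may bear on it.

Measured compounds in a functional assay on the whole organism (strain Wistar) for inhibition, with Rattus norvegicus as the target, read by paw edema, with stated times of 60 min and 2 h, at a dose of 100 mg/kg by the oral route; a lower number here means less inhibition, a higher number more inhibition at the dose given (going by the name of the read-out):

compound 1, `CNC(=O)CC1CCc2cc(OC)c(OC)cc21`: compound 1 gives 30%
compound 2, `COc1cc2c(cc1OC)C(CC(=O)NC(C)C)CC2`: compound 2 gives 37%
compound 3, `COc1cc2c(cc1OC)C(CC(=O)NC1CCCCC1)CC2`: compound 3 gives 56%

Compound 2 stands second highest of the three numbers. Its nearest neighbour is compound 1, whose number is within the scatter of it; the furthest is compound 3, beyond the scatter. Compound 4, `COc1cc2c(cc1OC)C(CC(=O)NCc1ccccc1)CC2`, has not yet been measured in this assay. The change from compound 2 to compound 4 is benzyl in place of isopropyl on an amide-type nitrogen. The shared core and the amide are kept; only the group on the amide-type nitrogen is exchanged.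

Among the measured compounds shown here, three measured steps touch this place. a number 7 percentage points higher from compound 1 to compound 2 (within the scatter); a number 19 percentage points higher from compound 2 to compound 3 (beyond the scatter); a number 26 percentage points higher from compound 1 to compound 3 (beyond the scatter). Every enlargement of the group on the amide-type nitrogen so far reads either unchanged within the scatter or higher, never lower. Benzyl carries a six-membered ring, as cyclohexyl does, but an aromatic one, and no measured step covers an aromatic ring at this place, so the expected rise is set smaller than that from compound 2 to compound 3 while still in the same direction: a number 11 percentage points higher from compound 2 to compound 4 (beyond the scatter) is expected, near the edge of the scatter.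

Compound 4 is therefore estimated at 48%, with a range from 34% to 62%.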

Compound 4, a percentage reported as inhibition, in the whole organism at one dose (the size of the read-out at that dose, not a potency): 24%
Compound 4: the middle estimate sits 24 percentage points above what was measured; the measured number lies below the stated range.
By their numbers in this assay, from the lowest: compounds 4, 1 and 2 (each within the scatter of the next, the first and the last beyond it); then compound 3.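

In this assay, enlarging the group on the amide-type nitrogen no longer reads only as unchanged or higher: benzyl in place of isopropyl gives a number 13 percentage points lower from compound 2 to compound 4 (beyond the scatter), and benzyl in place of cyclohexyl gives a number 32 percentage points lower from compound 3 to compound 4 (beyond the scatter), so a six-membered ring at this place does not by itself go with the higher number. Phenyl in place of hydrogen on the saturated chain carbon bound to the amide-type nitrogen gives a number 6 percentage points lower from compound 1 to compound 4 (within the scatter), which leaves benzyl level with methyl, while cyclohexyl is the only group shown that stands beyond the scatter of all the others. No measurement at hand bears on the reason for this drop.

The compounds shown leave open whether the loss from cyclohexyl to benzyl follows from the aromatic ring or from the added carbon link to the nitrogen, a question that cyclohexylmethyl and phenyl on the amide-type nitrogen would separate. They also leave open whether a longer chain such as 2-phenylethyl, or a ring-bearing group with a nitrogen in it such as a piperidine, would follow cyclohexyl or benzyl.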